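This account rests on a few compounds, and the source may have more. Where it says the series, first, only, none or still open, it means among the compounds named here.

Compound 1 `Cc1ccc(Nc2ncc(C(F)(F)F)c(N3Cc4cccc(N(C)S(C)(=O)=O)c4C3)n2)cc1C` was tested in a functional assay on OVCAR-3 cells (Homo sapiens) for antiproliferative activity, read by spectrophotometry, with a stated time of 2 days; a higher number here means a weaker inhibitor of growth, a lower number a stronger inhibitor of growth. There compound 1 gives only a limit, not a number: > 30000 nM. Compound 2 `CN(c1cccc2c1CN(c1nc(Nc3cc(C(F)(F)F)cc(C(F)(F)F)c3)ncc1C(F)(F)F)C2)S(C)(=O)=O` likewise gives only a limit in this assay, namely > 30000 nM. Compound 1 thus stands at the limit of > 30000 nM in this assay, at which 2 of the 2 values shown sit. Compound 3 `CN(c1cccc2c1CN(c1nc(Nc3ccc(C(F)(F)F)cc3)ncc1C(F)(F)F)C2)S(C)(=O)=O` differs from compound 1 in one place: 4-(trifluoromethyl)phenyl in place of 3,4-dimethylphenyl on a nitrogen on an aromatic ring. Among the compounds with values here, with no measured step between compounds to lean on, the change expected in this assay is a number no higher from compound 1 to compound 3 (the limit leaves the size open), nothing beyond the usual scatter. Compound 3 is expected to give about 30000 nM, between 10000 nM and 100000 nM, most likely again only a limit.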

Compound 3, concentration for 50% growth inhibition: > 30000 nM
Compound 3 ended at the assay's limit; the forecaster's own chance of this, stated with the estimate: 80%; the middle value sits exactly at the limit.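

Compound 1 and compound 3 both give only a limit, so no step between them can be read: the limit of > 30000 nM in this assay, at which 3 of the 3 values shown sit.

The compounds shown leave open whether any other group on a nitrogen on an aromatic ring would give a real number rather than a limit.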